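Dropping an Amino Group from a Fused-Ring Ketone

The compounds below may be only part of what the source reports. "The series", "measured", "known", "first", "only" and "open" are said of these compounds alone.

Measured so far:
Compound 1, `CN(c1ccc(F)c(O)c1)c1cccc(-c2cccc(O)c2F)n1`: 100%
Compound 2, `Nc1ccc2ccc(C(=O)c3ccc(F)c(O)c3)nc2c1`: 83%
Compound 3, `O=C(c1ccc(F)c(O)c1)c1ccc2ccccc2c1`: 96%

Of the compounds shown here, three have been tested in an assay for inhibition of 17-beta-hydroxysteroid dehydrogenase type 2 (Homo sapiens), read by HPLC, with a stated time of 10 min, tested at 1 uM; on this read-out lower numbers stand for less inhibition and higher numbers for more inhibition at the one concentration tested (going by the name of the read-out). Compound 2 stands lowest of the three numbers. Its nearest neighbour is compound 3, which in this assay gives 96%, a number beyond the scatter above compound 2. Compound 1 lies furthest away, also beyond the scatter. For the measured compounds named here, none of the three pairs differs in only one place, so no single step between measured compounds can be read off.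

Compound 4, `O=C(c1ccc(F)c(O)c1)c1ccc2ccccc2n1`, has not yet been measured. It differs from compound 2 in one place: hydrogen in place of amino on an aromatic carbon. Compound 3 also carries no amino group and gives 96%, so losing the amino group is not expected to lower the number. In this assay the step is expected to go upward, but by an amount within the usual scatter. The estimate for compound 4 is 90%, with a range from 78% to 98%, which means an expected step of a number 7 percentage points higher from compound 2 to compound 4 (within the scatter).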

Compound 4, a percentage reported as inhibition, at one concentration (the size of the read-out at that concentration, not a potency): 76%
Compound 4: middle estimate off by 14 percentage points, on the high side; the whole stated range lies above it.
By their numbers in this assay, from the lowest: compounds 4 and 2 (each within the scatter of the next); then compounds 3 and 1 (each within the scatter of the next).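

In this assay, putting hydrogen in place of amino on the aromatic carbon gives a number 7 percentage points lower from compound 2 to compound 4 (within the scatter). For the compounds shown here, this is the first comparison here of two compounds that differ in one place, and it shows that, for this pair, removing the amino group from this six-membered aromatic ring of carbon only, part of a fused system, leaves the read-out within the usual scatter. No measurement available here explains this result.

The compounds shown leave open what other groups on this same aromatic carbon would do, such as a methoxy group, a carboxylic acid or a longer chain ending in an amine. One pair also cannot show whether hydrogen in place of amino would have the same outcome on a different core.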